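Removing the amine-bearing side chain from compound 2

The compounds below may be only part of what the source reports. "The series", "measured", "known", "first", "only" and "open" are said of these compounds alone.

Of the compounds shown here, two of a shared core have been measured in a functional assay (Homo sapiens) for antiproliferative activity, read by resazurin assay, with a stated time of 48 h, tested at 10 uM; on this read-out higher numbers stand for a stronger effect at the one concentration tested and lower numbers for a weaker effect. Compound 1 `COc1cc(OC)c2c(=O)cc(-c3ccc(OCCCN)cc3)oc2c1` gives 39% in this assay. Among the compounds with values here, compound 2 `COc1cc(OC)c2c(=O)cc(-c3ccc(OCC(O)CN(C)C)cc3)oc2c1` gives 60% in this assay, the higher of the two numbers; the one step that separates them, a number 21 percentage points higher from compound 1 to compound 2 (beyond the scatter), exchanges one side chain for another while keeping a chain on that oxygen.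

Compound 3 `COc1cc(OC)c2c(=O)cc(-c3ccc(Br)cc3)oc2c1` differs from compound 2 in a single place: bromo in place of 3-(dimethylamino)-2-hydroxypropoxy on an aromatic carbon. Within the data shown here, the one measured step compares two side chains bound through an oxygen, whereas here the whole chain, together with its oxygen, gives way to a single bromine atom. Among the measured compounds shown here, no measured step therefore covers this change directly, and the expectation rests on little: the only firm point is that the chain variant carrying no hydroxyl and a plain amine, compound 1, reached 39%. On that basis compound 3 is expected to fall somewhat below compound 2, with an expected step of a number 25 percentage points lower from compound 2 to compound 3 (beyond the scatter), though a result anywhere within a wide band would not surprise. The estimate for compound 3 is 35%, between 10% and 65%.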

Compound 3, a percentage reported as inhibition, at one concentration (the size of the read-out at that concentration, not a potency): 10%
Compound 3: the middle estimate sits 25 percentage points above what was measured; the range from low to high includes it.
By their numbers in this assay, from the lowest: compound 3; then compound 1; then compound 2.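

In this assay the change to bromo on this aromatic carbon brings a number 50 percentage points lower from compound 2 to compound 3 (beyond the scatter) and, starting from the shorter amine chain, a number 29 percentage points lower from compound 1 to compound 3 (beyond the scatter) as well. Within the data shown here, the earlier pair compared only one oxygen-bound chain with another, so it could not show what happens when the chain and its oxygen are gone altogether; here both chains stand above the single bromine atom, with no compound of the three going against this, and the larger step starts from the 3-(dimethylamino)-2-hydroxypropoxy chain. Nothing available explains why the numbers fall in this way.

The swap to bromo removes the oxygen, the carbon chain and the nitrogen in one move, and adds a bromine atom, so these compounds cannot tell which of those parts accounts for the difference. A plain propoxy chain with no amine at its end, or a single methoxy group at this place, would help to separate the share of the nitrogen from that of the chain and the oxygen.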